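Extending the chain from compound 2 to compound 3

The source may report more compounds than this note shows. Statements on the series, on what has been measured and on what is new or still open speak of the compounds shown alone.

In a functional assay on EC9706 cells (Homo sapiens) for antiproliferative activity, read by MTT assay, with a stated time of 48 h (on this read-out higher numbers stand for weaker inhibition and lower numbers for stronger inhibition), compound 1 (`CCCCCCCn1cc(COC[C@@H]2OC[C@H](N)[C@@H]2O)nn1`) reads > 128000 nM and this is a limit, not a number. For the measured compounds named here, compound 2 (`CCCCCCCCCn1cc(COC[C@@H]2OC[C@H](N)[C@@H]2O)nn1`) gives 20100 nM and stands as the only number. Compound 3 (`CCCCCCCCCCCCCCCCn1cc(COC[C@@H]2OC[C@H](N)[C@@H]2O)nn1`) differs from compound 2 by heptyl in place of hydrogen on a saturated chain carbon, nine bonds along the chain from an aromatic nitrogen and the same difference also reads ethyl to nonyl. Going by the values given here, one measured step bears on this change, namely an at least 6.3-fold lower number from compound 1 to compound 2 (0.80 log units; beyond the scatter) and it also lengthens the chain. That step starts from the limit of > 128000 nM in this assay, at which 1 of the 2 values shown sits, and so has no upper size. A further fall in this assay is expected, but a single step cannot show whether the trend holds over so large an addition. The expected change is a 3.4-fold lower number from compound 2 to compound 3 (0.53 log units; beyond the scatter) in the direction of stronger inhibition. Compound 3 is estimated at 6000 nM with an expected range from 1500 nM to 25000 nM in this read-out.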

Compound 3, half-maximal inhibitory concentration: 20000 nM
Beside the measured number, compound 3's estimate is 3.3-fold (0.52 log units) below it; low and high end bracket the measured number.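

In this assay, heptyl at this place, nine bonds along the chain from an aromatic nitrogen, gives a 1.0-fold lower number from compound 2 to compound 3 (0.00 log units; within the scatter), so the two compounds read alike and the fall seen with the earlier lengthening does not carry on to this much longer chain. Compound 3 keeps the advantage over the shorter chain, with an at least 6.4-fold lower number from compound 1 to compound 3 (0.80 log units; beyond the scatter). The true size of that step stays unknown, since compound 1 stands at a limit and not a number: the limit of > 128000 nM in this assay, at which 1 of the 3 values shown sits.

The compounds shown leave open how a chain of intermediate length, such as dodecyl, would read in this assay, and so whether the series has a lower number somewhere between compound 2 and compound 3. Also open, from the compounds shown here alone, is how an amine or a carboxylic acid at the end of the chain would read.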